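Replacing the fluorophenyl arm: notes toward compound 4

A few compounds are considered here, and "the series" means these few. Any claim that something is new, unique, unknown or untested is made for them only; others in the source may bear on it.

Measured so far:
compound 1 `O=C(CCCCCCc1ccccc1)c1ncc(-c2ccccc2C(=O)C(F)(F)F)o1` — 5000 nM
compound 2 `O=C(CCCCCCc1ccccc1)c1ncc(-c2ccc(F)cc2)o1` — 62 nM
compound 3 `O=C(CCCCCCc1ccccc1)c1ncc(-c2ccc(C(=O)C(F)(F)F)cc2)o1` — 65 nM

In an assay (Rattus norvegicus) for inhibition of Fatty-acid amide hydrolase 1 (Homo sapiens) (a lower number here means a stronger inhibitor, a higher number a weaker inhibitor), compound 2 carries the lowest of the three numbers; compound 3 sits within the scatter of it, while compound 1 lies far higher. The new analogue, compound 4 `NS(=O)(=O)c1ccc(-c2cnc(C(=O)CCCCCCc3ccccc3)o2)s1`, departs from compound 2 by 5-sulfamoylthiophen-2-yl in place of 4-fluorophenyl on an aromatic carbon. Among the compounds with values here, only one measured step bears on this: a 1.0-fold higher number from compound 2 to compound 3 (0.02 log units; within the scatter), which shows the ring at this place accepting a large substituent in place of fluoro without loss. Within the data shown here, no measured compound carries a different ring here, nor a sulfamoyl group, so the step stays open in either direction. The expectation for compound 4 is a 1.6-fold lower number from compound 2 to compound 4 (0.19 log units; within the scatter). Compound 4 is therefore estimated at 40 nM, within 8 nM to 200 nM.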

Compound 4, inhibition constant: 3 nM
Compound 4: middle estimate off by 13-fold (1.12 log units), on the high side; measured number below the stated range.
By their numbers in this assay, from the lowest: compound 4; then compounds 2 and 3 (each within the scatter of the next); then compound 1.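

The aromatic carbon next to the ring oxygen does more than accept a large substituent: 5-sulfamoylthiophen-2-yl in place of 4-fluorophenyl gives, in this assay, a 21-fold lower number from compound 2 to compound 4 (1.32 log units; beyond the scatter), whereas the earlier change gave only a 1.0-fold higher number from compound 2 to compound 3 (0.02 log units; within the scatter). This single step changes both the ring and its substituent, so it does not assign the gain to either. No evidence on the origin of the gain is at hand.

Open, as far as these compounds go, is whether 4-sulfamoylphenyl would keep the low number, which would separate the sulfamoyl group from the five-membered ring. Also open, from the compounds shown here alone, is how a carboxylic acid or a methylsulfonyl group would compare in place of the sulfamoyl group.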